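This account rests on a few compounds, and the source may have more. Where it says the series, first, only, none or still open, it means among the compounds named here.

Values in a functional assay on the whole organism for antagonist activity, with Mus musculus as the target; on this read-out higher numbers stand for an effect only at larger amounts of compound and lower numbers for an effect already at smaller amounts:

compound 1, `CC(C#CCn1ccnc1)N1CCCC1=O`: 3.7 mg/kg
compound 2, `Cc1cncn1CC#CC(C)N1CCCC1=O`: 2.5 mg/kg
compound 3, `COC(=O)N(C)CC#CCn1ccnc1`: > 100 mg/kg

For compound 3 this reading is a limit of the assay, not a number, as marked by the limit of > 100 mg/kg in this assay, at which 1 of the 3 values shown sits. Between the first two compounds the measured step is a 1.5-fold lower number from compound 1 to compound 2 (0.17 log units; within the scatter), made by the change (methyl in place of hydrogen on an aromatic carbon). How the core of compound 3 differs from the core of compound 1 is not broken down here; the two values show compound 1 with a number and compound 3 with only a limit.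

Compound 4, `COC(=O)N(C)CC#CCn1cncc1C`, carries the same change on the core of compound 3: methyl in place of hydrogen on an aromatic carbon. In this assay the step expected is a step that the limit leaves unreadable from compound 3 to compound 4, an expectation that rests on the measured step of a 1.5-fold lower number from compound 1 to compound 2 (0.17 log units; within the scatter) having stayed within the scatter. Compound 4 is therefore estimated at 120 mg/kg, most likely again reported only as a limit.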

Compound 4, dose for half-maximal effect: 5.4 mg/kg
The estimate for compound 4 lay 22-fold (1.35 log units) above the measured number; the whole stated range lies above it.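

In this assay the methyl in place of hydrogen on an aromatic carbon gives an at least 18-fold lower number from compound 3 to compound 4 (1.26 log units; beyond the scatter), so the size of this step does not carry over unchanged between these two cores: the same change on two cores in this assay, a 1.5-fold lower number (0.17 log units; within the scatter) from compound 1 to compound 2 and an at least 18-fold lower number (1.26 log units; beyond the scatter) from compound 3 to compound 4, at least 12-fold (1.09 log units) apart, beyond the scatter of two such steps

For compound 3 the reading is a limit of the assay, not a number: the limit of > 100 mg/kg in this assay, at which 1 of the 4 values shown sits.

The two cores show that the size of the step differs with the core, but not which feature of the cores sets that gap, nor how the change behaves on any other core.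

Open, going by these compounds, is whether ethyl or a chlorine atom in place of that methyl would keep the reading of compound 4 in this assay. Also open, on these data alone, is whether a core ending in an amine would show the small step or the large one.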